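A few compounds are considered here, and "the series" means these few. Any claim that something is new, unique, unknown or untested is made for them only; others in the source may bear on it.

Compound 2 `COC(=O)[C@H](CO)NC(=O)c1cnc2ccc(Cl)cc2c1Cl` carries two chloro groups on the shared core. In an ADME assay on CCRF-CEM cells (Homo sapiens) for cytotoxicity (a lower number here means that less compound is tolerated, a higher number that more compound is tolerated), compound 2 gives > 100 uM, which is a limit of the assay rather than a number. Compound 1 `COC(=O)[C@H](CO)NC(=O)c1cnc2ccccc2c1Cl` lacks the second chloro. In this assay compound 1 gives > 100 uM, again a limit. The step that the two limits leave unreadable from compound 1 to compound 2 thus cannot be read. The whole evidence so far is the limit of > 100 uM in this assay, at which 2 of the 2 values shown sit.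

Compound 3 `COC(=O)[C@H](CO)NC(=O)c1cnc2ccc(F)cc2c1Cl` follows from compound 2 by fluoro in place of chloro on an aromatic carbon. Among the compounds with values here, the only measured step touching this position is the one from compound 1 to compound 2, and its size is not readable, so the data give no size for swapping one halogen for another there. With compound 2 at a limit, no step beyond the scatter in this assay is expected, and compound 3 is expected to sit at the limit as well, the step being a step that the limit leaves unreadable from compound 2 to compound 3. For compound 3 the estimate is 150 uM, between 50 uM and 400 uM.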

Compound 3, half-maximal toxic concentration: > 100 uM
Compound 3 ended at the assay's limit (the forecaster's own chance of this, stated with the estimate: 85%); the middle value lies beyond the limit too.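

No new step can be read among compound 1, compound 2 and compound 3 in this assay, because each value is a limit of the assay: the limit of > 100 uM in this assay, at which 3 of the 3 values shown sit.

Still open, as far as these compounds go, is how much compound each of the three tolerates, and whether hydrogen, chloro or fluoro at this position makes any difference.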